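The source may report more compounds than this note shows. Statements on the series, on what has been measured and on what is new or still open speak of the compounds shown alone.

Measured so far:
Compound 1, `Cc1nn(-c2nc(-c3ccc(Cl)c(Cl)c3)c(SC(C)C)s2)c(C(=O)O)c1-c1cncnc1` — 22000 nM
Compound 2, `COc1ccccc1-c1c(C)nn(-c2nc(-c3ccc(Cl)c(Cl)c3)c(SC(C)C)s2)c1C(=O)O` — 14700 nM
Compound 3, `Cc1nn(-c2nc(-c3ccc(Cl)c(Cl)c3)c(SC(C)C)s2)c(C(=O)O)c1-c1ccccc1Cl` — 13100 nM

These three compounds share one core and differ only in the aromatic group on the five-membered ring. In a functional assay on BJAB cells (Homo sapiens) for antiproliferative activity, with a stated time of 4 days (on this read-out higher numbers stand for an effect only at larger amounts of compound and lower numbers for an effect already at smaller amounts), compound 1 gives 22000 nM, compound 2 gives 14700 nM and compound 3 gives 13100 nM. Compound 3 shows the smallest number of the three, yet a 1.7-fold lower number from compound 1 to compound 3 (0.23 log units; within the scatter) and a 1.1-fold lower number from compound 2 to compound 3 (0.05 log units; within the scatter) are both within the scatter, so the three compounds cannot really be told apart on these data.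

Compound 4, `Cc1cc(C)cc(-c2c(C)nn(-c3nc(-c4ccc(Cl)c(Cl)c4)c(SC(C)C)s3)c2C(=O)O)c1`, carries the change (3,5-dimethylphenyl in place of 2-chlorophenyl on an aromatic carbon). Every step seen so far at this position, a 1.5-fold lower number from compound 1 to compound 2 (0.18 log units; within the scatter), a 1.7-fold lower number from compound 1 to compound 3 (0.23 log units; within the scatter) and a 1.1-fold lower number from compound 2 to compound 3 (0.05 log units; within the scatter), stayed within the scatter, whether the group was a ring with nitrogen, a methoxyphenyl or a chlorophenyl. Nothing in the data points to a larger effect for a dimethylphenyl. Compound 4 is therefore expected to give 13000 nM, with a range from 6000 nM to 30000 nM. The expected step of a 1.0-fold lower number from compound 3 to compound 4 (0.00 log units; within the scatter) is estimated to lie within the scatter.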

Compound 4, half-maximal effective concentration: 2700 nM
Beside the measured number, compound 4's estimate is 4.8-fold (0.68 log units) above it; measured number below the stated range.
By their numbers in this assay, from the lowest: compound 4; then compounds 3, 2 and 1 (each within the scatter of the next).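

Among the groups shown at this position, 3,5-dimethylphenyl is the first to stand apart in this assay: there is a 4.9-fold lower number from compound 3 to compound 4 (0.69 log units; beyond the scatter), a 5.4-fold lower number from compound 2 to compound 4 (0.74 log units; beyond the scatter) and an 8.1-fold lower number from compound 1 to compound 4 (0.91 log units; beyond the scatter), all modest but beyond the scatter. The position therefore does respond to the choice of aromatic group, and a six-membered ring of carbon only is not enough on its own, since compound 2 and compound 3 also carry one. No measurement shown here bears on why the 3,5-dimethylphenyl group stands apart.

As far as these compounds go, it remains open whether plain phenyl or a ring with a single methyl group would give a number like that of compound 4, or whether both methyl groups are required. From the compounds shown here alone, how ethyl, methoxy or amine groups would behave in place of those methyl groups also remains open.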